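The compounds below may be only part of what the source reports. "The series", "measured", "known", "first", "only" and "open" are said of these compounds alone.

In a functional assay on MCF7 cells (Homo sapiens) for cytotoxicity, read by CellTiter-Glo, with a stated time of 5 days (a lower number here means a stronger inhibitor, a higher number a weaker inhibitor), compound 1 `O=C(O)/C=C/c1ccc(/C(=C(\c2ccccc2)C2CC2)c2ccc3[nH]ncc3c2)cc1` gives 13 nM. Compound 2 `CC/C(=C(/c1ccc(/C=C/C(=O)O)cc1)c1ccc2[nH]nc(C)c2c1)c1ccccc1` is reported in this assay only as a limit, > 1000 nM, and so stands at the limit of > 1000 nM in this assay, at which 1 of the 2 values shown sits, rather than at a measured number. Compound 3 `CC/C(=C(/c1ccc(/C=C/C(=O)O)cc1)c1ccc2[nH]ncc2c1F)c1ccccc1` carries 4-fluoro-1H-indazol-5-yl in place of 3-methyl-1H-indazol-5-yl on a double-bonded chain carbon bound to an aromatic carbon and a double-bonded chain carbon. Going by the values given here, because the value of compound 2 is a limit > 1000 nM, no measured step is available, yet compound 1 shows that the shared core can reach strong inhibition with an unsubstituted indazole. The step from compound 2 to compound 3 in this assay is therefore expected to be a gain well beyond the scatter, an at least 10-fold lower number from compound 2 to compound 3 (1.00 log units; beyond the scatter). Compound 3 is estimated at 100 nM, with a range from 20 nM to 600 nM.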

Compound 3, half-maximal inhibitory concentration: 3 nM
Beside the measured number, compound 3's estimate is 33-fold (1.52 log units) above it; measured number outside the range, below it.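

In this assay, putting 4-fluoro-1H-indazol-5-yl in place of 3-methyl-1H-indazol-5-yl, with the rest of the structure unchanged, gives an at least 330-fold lower number from compound 2 to compound 3 (2.52 log units; beyond the scatter). Going by these compounds alone, this is the first readable step at this position, and it shows that a change confined to this one group can decide between strong inhibition and none detected within the range tested. The step rests on a limit, so its true size is not fixed: the limit of > 1000 nM in this assay, at which 1 of the 3 values shown sits.

The compounds shown do not separate losing the methyl from gaining the fluorine. As far as these compounds go, whether a chlorine or a methoxy group in place of that fluorine would keep this strength in this assay also stays open.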